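The source may hold more compounds than are shown below. What is called first, only, known or untested is meant among the compounds shown, and "the series" means these compounds.

Three compounds with a measured number stand in view here. Compound 1 `CCCc1cc(C(=O)N[C@H](C)CCCc2cccnc2)ccc1-c1ccc(OC)c(OC)c1` gives, in an assay (Canis lupus familiaris) for binding affinity to platelet-activating factor receptor (Homo sapiens), read by radioligand binding (a lower number here means a stronger inhibitor, a higher number a weaker inhibitor), a value of 50 nM. Compound 2 `COc1ccc(-c2ccc(C(S)=N[C@H](C)CCCc3cccnc3)cc2)cc1OC` gives in this assay 60 nM, and its number sits within the scatter of that of compound 1. Compound 3 `O=C(NCCCCc1cccnc1)c1ccc(-c2ccccc2)c(-c2ccccc2)c1`, the third measured compound, gives 5 nM, a number that lies beyond the scatter below compound 1; compound 1 therefore stands with the second highest of the three numbers, its nearest neighbour being compound 2 and its furthest compound 3.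

The step to follow leads from compound 1 to compound 4 `COc1ccc(-c2ccc(C(=O)N[C@H](C)CCCc3cccnc3)cc2Br)cc1OC`, which has not yet been measured. The change is bromo in place of propyl on an aromatic carbon, on an aromatic carbon of a six-membered aromatic ring of carbon only, ortho to a 3,4-dimethoxyphenyl group and meta to a large group. For the measured compounds named here, no measured pair in this set shows the same change, so the data give no step to lean on. The expectation is a step of no size beyond the scatter, a 1.2-fold higher number from compound 1 to compound 4 (0.08 log units; within the scatter), since the rest of compound 1 is kept. Compound 4 is thus estimated at 60 nM, with a range from 20 nM to 180 nM.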

Compound 4, half-maximal inhibitory concentration: 180 nM
Beside the measured number, compound 4's estimate is 3.0-fold (0.48 log units) below it; low and high end bracket the measured number.
By their numbers in this assay, from the lowest: compound 3; then compounds 1 and 2 (each within the scatter of the next); then compound 4.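

In this assay, for the compounds shown here, bromo in place of propyl on this aromatic carbon gives a 3.6-fold higher number from compound 1 to compound 4 (0.56 log units; beyond the scatter) and is the first single change in the set that can be read as a step. It shows that this position, ortho to a 3,4-dimethoxyphenyl group and meta to a large group, is not indifferent to what it carries: with the rest of compound 1 kept, this exchange moves the number beyond the scatter, towards a weaker inhibitor. Nothing at hand gives a reason for this step.

The compounds shown leave open how a methyl, an ethyl, a chloro or a methoxy group, or a chain longer than propyl, would stand on this same carbon. One step alone cannot tell whether the number follows the length of the carbon chain or the bromine itself.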